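Aryl ether variation on the shared core: estimate for compound 3

The source may hold more compounds than are shown below. What is called first, only, known or untested is meant among the compounds shown, and "the series" means these compounds.

Compound 2 `Cc1cc(Oc2ccc(/C=N/n3c(-c4ccccc4)nc4ccccc4c3=O)cc2)ccc1Cl` gives 6.52 in a physicochemical assay for lipophilicity, in phosphate buffer, measured as octanol-water partition (a lower number here means a more polar compound, a higher number a more lipophilic compound), and compound 1 `Cc1ccc(Oc2ccc(/C=N/n3c(-c4ccccc4)nc4ccccc4c3=O)cc2)cc1` gives 6.29; the two values lie within the scatter of each other, so neither stands apart. Going by the values given here, the one measured step, a number 0.23 log units higher from compound 1 to compound 2 (within the scatter), is the only precedent. Compound 3 `O=c1c2ccccc2nc(-c2ccccc2)n1/N=C/c1ccc(Oc2ccc(F)cc2)cc1` differs from compound 2 by 4-fluorophenyl in place of 4-chloro-3-methylphenyl on an oxygen on an aromatic ring. That measured step covers only part of this change, so a larger step, toward a lower number, is expected, namely a number 0.72 log units lower from compound 2 to compound 3 (beyond the scatter). Compound 3 is therefore estimated at 5.8, with a range from 5.3 to 6.3.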

Compound 3, partition coefficient: 6.21
The estimate for compound 3 lay 0.41 log units below the measured number; the range from low to high includes it.
By their numbers in this assay, from the lowest: compounds 3, 1 and 2 (each within the scatter of the next, the first and the last beyond it).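

In this assay, going by these compounds alone, the change to 4-fluorophenyl from 4-chloro-3-methylphenyl on an oxygen on an aromatic ring gives a number 0.31 log units lower from compound 2 to compound 3 (beyond the scatter) and is the only step so far to clear the scatter. Fluoro in place of methyl on an aromatic carbon gives a number 0.08 log units lower from compound 1 to compound 3 (within the scatter) and does not separate the two compounds. Nothing available gives a cause for either step.

The groups on this oxygen all remain substituted phenyl rings with no net charge. From the compounds shown here alone, how 4-chlorophenyl alone, or a phenyl ring carrying an amine or a carboxylic acid, would compare remains open.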